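Hydrogen in place of the ester methyl group

The compounds below may be only part of what the source reports. "The series", "measured", "known", "first", "only" and "open" are said of these compounds alone.

Compound 1, `O=C(OCCCc1ccccc1)c1cc(-n2cc(-c3cccc(O)c3)nn2)ccc1O`: 11%
Compound 2, `COC(=O)c1cc(-n2cc(-c3cccc(O)c3)nn2)ccc1O`: 6%

Of the compounds shown here, two have been measured in a functional assay on HCT-116 cells (Homo sapiens) for inhibition, read by MTT assay, with a stated time of 2 days, tested at 10 uM; a lower number here means less inhibition, a higher number more inhibition at the concentration tested (going by the name of the read-out). Compound 1 gives 11%, and compound 2 gives 6%. Both numbers are small, and they lie within the usual scatter of each other, so compound 2 cannot be told apart from compound 1 on this evidence: a number 5 percentage points lower from compound 1 to compound 2 (within the scatter).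

Compound 3, `O=C(O)c1cc(-n2cc(-c3cccc(O)c3)nn2)ccc1O`, has not yet been measured. It differs from compound 2 in one place: hydrogen in place of methyl on an oxygen next to a carbonyl group. Within the data shown here, the only measured step that bears on this change is the one from compound 1 to compound 2, which also altered the group on the oxygen next to the carbonyl, and that step stayed within the scatter. With the whole series sitting near the bottom of the scale, no move beyond the scatter is expected in this assay in either direction, so compound 3 is expected to give 6%, within -6% to 20%, a step of no change at the digits printed from compound 2 to compound 3 (within the scatter) that is itself expected to be within the scatter.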

Compound 3, a percentage reported as inhibition, at one concentration (the size of the read-out at that concentration, not a potency): 5%
Compound 3: middle estimate off by 1 percentage points, on the high side; the measured number falls inside the stated range.
By their numbers in this assay, from the lowest: compounds 3, 2 and 1 (each within the scatter of the next).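

Replacing the methyl on this oxygen with hydrogen, which turns methoxycarbonyl into carboxy, gives a number 1 percentage points lower from compound 2 to compound 3 (within the scatter) in this assay and so cannot be told apart from no change. Removing the whole 3-phenylpropyl group from the same oxygen gives a number 6 percentage points lower from compound 1 to compound 3 (within the scatter) and also stays inside the usual spread of repeat measurements, so the free carboxy form now sits with the two esters, all three with small numbers. Nothing measured here offers a reason for this flat picture.

The compounds shown leave open whether any other group at this place, such as an amide in place of the ester, could lift the number in this assay clear of the scatter. They also leave open whether a change elsewhere on the shared core, such as an amine in place of either hydroxy group, would do more than these changes on the oxygen next to the carbonyl group.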